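This account rests on a few compounds, and the source may have more. Where it says the series, first, only, none or still open, it means among the compounds named here.

Working notes on the ester series.

Compound 1 `COc1ccc(C(=O)OC2(C(=O)Nc3ccc([N+](=O)[O-])cc3)CCCCC2)cc1` gives 38.8 nM in a functional assay on NFS-60 cells (Mus musculus) for inhibition, read by MTT assay, with a stated time of 72 h; a higher number here means a weaker inhibitor, a lower number a stronger inhibitor. Compound 2 `O=C(OC1(C(=O)Nc2ccc([N+](=O)[O-])cc2)CCCCC1)c1ccc(Br)cc1` gives 236 nM in this assay, and the step of a 6.1-fold higher number from compound 1 to compound 2 (0.78 log units; beyond the scatter) is the widest spread in the set. Compound 3 `O=C(/C=C/c1ccccc1)OC1(C(=O)Nc2ccc([N+](=O)[O-])cc2)CCCCC1` gives 50.5 nM in this assay; it holds the second highest number of the three, with compound 1 nearest (a 1.3-fold higher number from compound 1 to compound 3 (0.11 log units; within the scatter)) and compound 2 furthest (a 4.7-fold lower number from compound 2 to compound 3 (0.67 log units; beyond the scatter)).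

Compound 4 `CCC(=O)OC1(C(=O)Nc2ccc([N+](=O)[O-])cc2)CCCCC1` differs from compound 3 by ethyl in place of 2-phenylethenyl on a carbonyl carbon. The two steps that alter the group on the carbonyl carbon, a 1.3-fold higher number from compound 1 to compound 3 (0.11 log units; within the scatter) and a 4.7-fold lower number from compound 2 to compound 3 (0.67 log units; beyond the scatter), swap one aryl or styryl ester for another and stay within or just beyond the scatter. Going by the values given here, no measured step removes the ring altogether, so the present change reaches further than any step on record, and the direction is not fixed by the data. Compound 4 is therefore expected to move only modestly, with a 2.2-fold higher number from compound 3 to compound 4 (0.34 log units; beyond the scatter) towards a somewhat higher number. Compound 4 is estimated at 110 nM, in a range from 30 nM to 450 nM.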

Compound 4, half-maximal inhibitory concentration: 6.4 nM
Compound 4: the middle estimate sits 17-fold (1.24 log units) above what was measured, and the stated range ends above it.
By their numbers in this assay, from the lowest: compound 4; then compounds 1 and 3 (each within the scatter of the next); then compound 2.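

At the carbonyl carbon of the ester, ethyl gives the lowest number of the four in this assay, with a 7.9-fold lower number from compound 3 to compound 4 (0.90 log units; beyond the scatter), a 6.1-fold lower number from compound 1 to compound 4 (0.78 log units; beyond the scatter) and a 37-fold lower number from compound 2 to compound 4 (1.57 log units; beyond the scatter). The earlier steps only exchanged one ring-bearing group for another, whereas these show that no aromatic ring is needed at this place for a low number, and that a group of 2 heavy atoms outdoes all three ring-bearing groups shown. Nothing measured on hand accounts for this change.

From the compounds shown here alone, it remains open how the number responds along a series of chains, from methyl to a longer chain such as butyl, and whether a saturated ring such as cyclohexyl behaves like ethyl or like the aromatic groups. The compounds shown also do not separate the loss of the aromatic ring from the loss of the double bond in 2-phenylethenyl.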